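From allylamino to hydroxy on a shared core

A few compounds are considered here, and "the series" means these few. Any claim that something is new, unique, unknown or untested is made for them only; others in the source may bear on it.

In a functional assay on CCRF-CEM cells (Homo sapiens) for cytotoxicity (on this read-out lower numbers stand for higher toxicity in this test and higher numbers for lower toxicity in this test), compound 1 `COc1nc(N)nc2c1ncn2C1CC(O)C(CO)S1` gives 8000 nM, compound 2 `Nc1nc(OCC2CC2)c2ncn(C3CC(O)C(CO)S3)c2n1` gives 41000 nM, and compound 3 `C=CCNc1nc(N)nc2c1ncn2C1CC(O)C(CO)S1` gives 60000 nM. Compound 3 therefore sits at the high, less toxic end of this small set, and a 1.5-fold higher number from compound 2 to compound 3 (0.17 log units; within the scatter) shows it level with compound 2. Compound 4 `Nc1nc(O)c2ncn(C3CC(O)C(CO)S3)c2n1` has not yet been measured. It differs from compound 3 by hydroxy in place of allylamino on an aromatic carbon, which means hydroxy in place of allylamino on an aromatic carbon. Among the compounds with values here, no measured step makes this exact exchange. The closest guide is a 7.5-fold higher number from compound 1 to compound 3 (0.88 log units; beyond the scatter), where methoxy gives way to allylamino; read in reverse, it suggests that removing allylamino in favour of an oxygen-linked group lowers the number. a 5.1-fold higher number from compound 1 to compound 2 (0.71 log units; beyond the scatter) also leaves methoxy with the lowest number of the three. Within the data shown here, a downward step at least as large as the one back to compound 1 therefore seems likely, though hydroxy itself is untested. The expected change in this assay is a 20-fold lower number from compound 3 to compound 4 (1.30 log units; beyond the scatter). Compound 4 is estimated at 3000 nM, within an expected range of 300 nM to 30000 nM.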

Compound 4, half-maximal cytotoxic concentration: 9000 nM
The estimate for compound 4 lay 3.0-fold (0.48 log units) below the measured number, and the stated range covers the measured number.
By their numbers in this assay, from the lowest: compounds 1 and 4 (each within the scatter of the next); then compounds 2 and 3 (each within the scatter of the next).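

In this assay the change from methyl to hydrogen on this oxygen cannot be read as a real change, with a 1.1-fold higher number from compound 1 to compound 4 (0.05 log units; within the scatter) in the test, so hydroxy stands level with methoxy. The two other groups separate clearly from hydroxy, with a 4.6-fold lower number from compound 2 to compound 4 (0.66 log units; beyond the scatter) and with a 6.7-fold lower number from compound 3 to compound 4 (0.82 log units; beyond the scatter) on the same aromatic carbon. An oxygen link alone therefore does not settle the number: cyclopropylmethoxy is also bound through oxygen, yet compound 2 stays level with compound 3 and its allylamino, while compounds 1 and 4 form a separate level pair.

Nothing measured here explains this split into two pairs. On these data alone, whether ethoxy, dimethylamino or a longer chain on the oxygen would fall with the lower pair or the higher pair remains open.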